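Swapping methylsulfanyl for aminoamino on a second core

A few compounds are considered here, and "the series" means these few. Any claim that something is new, unique, unknown or untested is made for them only; others in the source may bear on it.

Compound 1 `COc1ccc(-c2nc(SC)n(C)c(=O)c2C#N)cc1` gives 73 ug/mL in a functional assay, with a stated time of 150 min; a higher number here means a weaker inhibitor, a lower number a stronger inhibitor. Compound 2 `COc1ccc(-c2nc(NN)n(C)c(=O)c2C#N)cc1` carries one change, (aminoamino in place of methylsulfanyl on an aromatic carbon), and in this assay compound 2 gives 56 ug/mL, so that a 1.3-fold lower number from compound 1 to compound 2 (0.12 log units; within the scatter). Compound 3 `CSc1nc(-c2ccccc2O)c(C#N)c(=O)n1C` has a different core; the difference between the two cores is not broken down here. In this assay compound 3 gives 58 ug/mL. Compound 4 `Cn1c(NN)nc(-c2ccccc2O)c(C#N)c1=O` is not yet measured and differs from compound 3 by aminoamino in place of methylsulfanyl on an aromatic carbon. Among the measured compounds shown here, this is the same kind of change as the one from compound 1 to compound 2, though the surroundings differ: in compound 3 the carbon is meta to a group of 7 heavy atoms, in compound 1 meta to a group of 8 heavy atoms. Because the step of a 1.3-fold lower number from compound 1 to compound 2 (0.12 log units; within the scatter) was small, the expected step of a 1.3-fold lower number from compound 3 to compound 4 (0.11 log units; within the scatter) is also small. Compound 4 is therefore estimated at 45 ug/mL in this assay, with a likely range from 25 ug/mL to 80 ug/mL.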

Compound 4, half-maximal inhibitory concentration: 46 ug/mL
For compound 4 the middle estimate is 1.0-fold (0.01 log units) below the measured one; the range from low to high includes it.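

In this assay, replacing methylsulfanyl with aminoamino gives a 1.3-fold lower number from compound 3 to compound 4 (0.10 log units; within the scatter), so the step on this core is small. Set beside the same change on the core of compound 1, the two steps agree: the same change on two cores in this assay, a 1.3-fold lower number (0.12 log units; within the scatter) from compound 1 to compound 2 and a 1.3-fold lower number (0.10 log units; within the scatter) from compound 3 to compound 4, 1.0-fold (0.01 log units) apart, within the scatter of two such steps. This shows that the change carried over between these two cores as a step of similar small size, but it does not show that aminoamino gives a real gain in potency on either core, and two cores set no rule for a third.

The compounds shown leave open whether another group on this aromatic carbon, such as a simple amine or a longer chain, would give a step beyond the scatter. They also leave open how aminoamino behaves on other cores.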